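The source may hold more compounds than are shown below. What is called first, only, known or untested is meant among the compounds shown, and "the series" means these compounds.

Measured compounds:
- compound 1, `COc1ccc(NCC(=O)Oc2ccc3c(C)cc(=O)oc3c2)cc1`: in a functional assay on the whole organism (strain Wistar albino) for inhibition, with Rattus norvegicus as the target, read by paw edema, with stated times of 30 min and 1 h, at a dose of 20 mg/kg by the oral route (a lower number here means less inhibition, a higher number more inhibition at the dose given (going by the name of the read-out)), compound 1 gives 30.3%
- compound 2, `COc1ccccc1NCC(=O)Oc1ccc2c(C)cc(=O)oc2c1`: compound 2 gives 10.7%
- compound 3, `Cc1cc(=O)oc2cc(OC(=O)CNc3ccc(Cl)cc3)ccc12`: compound 3 gives 10.7%

All three share one core, an ester of a glycine-type linker carrying an aryl amine, and differ only in the substituent on that aryl ring. Compound 3 stands level with compound 2 at the digits given, and the two together are the lowest of the three numbers; the step of no change at the digits printed from compound 2 to compound 3 (within the scatter) lies within the scatter, while a number 19.6 percentage points lower from compound 1 to compound 3 (beyond the scatter) lies beyond it.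

Compound 4, `Cc1cc(=O)oc2cc(OC(=O)CNc3ccc([N+](=O)[O-])cc3)ccc12`, has not yet been measured. Compared with compound 3 the change is nitro in place of chloro on an aromatic carbon. Among the compounds with values here, no measured step swaps a chloro for a nitro; the closest bearing step is a number 19.6 percentage points lower from compound 1 to compound 3 (beyond the scatter), a modest drop when chloro replaced methoxy, and no change at the digits printed from compound 2 to compound 3 (within the scatter) shows no movement. With nothing pointing either way, the expected step of a number 1.3 percentage points higher from compound 3 to compound 4 (within the scatter) is small, likely within the scatter. Compound 4 is therefore estimated at 12%, in the range 2% to 28% in this assay.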

Compound 4, a percentage reported as inhibition, in the whole organism at one dose (the size of the read-out at that dose, not a potency): 12.5%
Estimate against measurement, compound 4: 0.5 percentage points below; measured number inside the range.
By their numbers in this assay, from the lowest: compounds 2, 3 and 4 (each within the scatter of the next); then compound 1.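

In this assay, nitro in place of chloro on an aromatic carbon, para to a large group, gives a number 1.8 percentage points higher from compound 3 to compound 4 (within the scatter), so exchanging this single atom for a group of three heavy atoms, two of them counted as hydrogen-bond acceptors, leaves the read-out within the scatter. Measured against methoxy at the same place, nitro gives a number 17.8 percentage points lower from compound 1 to compound 4 (beyond the scatter), so of the three groups tried on this carbon, only methoxy stands apart, although the 2-methoxyphenyl compound 2 shows that a methoxy group alone does not secure the higher number. No measurement here explains either result.

On these data alone, it remains open whether methoxy is an isolated case or whether other groups on this carbon, such as a hydroxyl, an amine or an ethoxy, would also stand above chloro and nitro. A single dose also leaves open how these compounds would compare at other doses.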